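Morpholin-4-yl to 2-methylpiperidin-1-yl on a sulfonyl sulfur

The source may hold more compounds than are shown below. What is called first, only, known or untested is meant among the compounds shown, and "the series" means these compounds.

In an in vitro ADME assay on microsomes from liver (Rattus norvegicus) for metabolic stability, read by LC-MS, tested at 1 uM (on this read-out higher numbers stand for fast clearance and lower numbers for slow clearance), compound 3 (`Cc1ccc(S(=O)(=O)N2CCOCC2)cc1C#Cc1cc(Cl)ccc1OCC(=O)O`) gives 10 mL.min-1.g-1 and compound 2 (`Cc1ccc(S(=O)(=O)NC(C)C)cc1C#Cc1cc(Cl)ccc1OCC(=O)O`) gives 12 mL.min-1.g-1. These two cannot be told apart, with a 1.2-fold lower number from compound 2 to compound 3 (0.08 log units; within the scatter). Compound 1 (`Cc1ccc(S(=O)(=O)N(C)C(C)C)cc1C#Cc1cc(Cl)ccc1OCC(=O)O`) stands apart at 64 mL.min-1.g-1, with a 5.3-fold lower number from compound 1 to compound 2 (0.73 log units; beyond the scatter) and a 6.4-fold lower number from compound 1 to compound 3 (0.81 log units; beyond the scatter). Compound 4 (`Cc1ccc(S(=O)(=O)N2CCCCC2C)cc1C#Cc1cc(Cl)ccc1OCC(=O)O`) carries 2-methylpiperidin-1-yl in place of morpholin-4-yl on a sulfonyl sulfur. The closest guide is a 6.4-fold lower number from compound 1 to compound 3 (0.81 log units; beyond the scatter), read in reverse: compound 1, like compound 4, has no hydrogen on the sulfonamide nitrogen and lacks the oxygen of morpholin-4-yl. The expected step is a 4.5-fold higher number from compound 3 to compound 4 (0.65 log units; beyond the scatter), a modest move to a higher number, beyond the scatter. For compound 4 the estimate is 45 mL.min-1.g-1, with an expected range of 18 mL.min-1.g-1 to 110 mL.min-1.g-1.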

Compound 4, intrinsic clearance in microsomes: 418 mL.min-1.g-1
For compound 4 the middle estimate is 9.3-fold (0.97 log units) below the measured one, and the stated range ends below it.
By their numbers in this assay, from the lowest: compounds 3 and 2 (each within the scatter of the next); then compound 1; then compound 4.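

On the sulfonyl sulfur, 2-methylpiperidin-1-yl gives compound 4 the highest number of the four in this assay, with a 42-fold higher number from compound 3 to compound 4 (1.62 log units; beyond the scatter) and a 35-fold higher number from compound 2 to compound 4 (1.54 log units; beyond the scatter). Even against compound 1, the highest number until now, there is a 6.5-fold higher number from compound 1 to compound 4 (0.81 log units; beyond the scatter), so this position spans a far wider range than the earlier compounds showed. Nothing available bears on the reason for these rises. The compounds shown leave open how much of the step goes with the ring methyl and how much with the loss of the morpholine oxygen. Unsubstituted piperidin-1-yl would separate the two.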